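Aryl fluorine pattern around the methoxy group

The compounds below may be only part of what the source reports. "The series", "measured", "known", "first", "only" and "open" are said of these compounds alone.

Measured in a functional assay on CHO cells for agonist activity at metabotropic glutamate receptor 2 (Homo sapiens), read by scintillation counting and GTPgammaS binding, with a stated time of 30 min; a higher number here means that more compound is needed for the effect, a lower number that less compound is needed:
compound 1 `Fc1ccc(C2CCN(c3ccn4c(CC5CC5)nnc4c3Cl)CC2)c(F)c1` gives 61.7 nM
compound 2 `COc1ccccc1C1CCN(c2ccn3c(CC4CC4)nnc3c2Cl)CC1` gives 20 nM
compound 3 `COc1c(C2CCN(c3ccn4c(CC5CC5)nnc4c3Cl)CC2)ccc(F)c1F` gives 26 nM

Compound 3 stands second highest of the three numbers in this assay. Its nearest neighbour is compound 2, with a 1.3-fold higher number from compound 2 to compound 3 (0.11 log units; within the scatter); its furthest is compound 1, with a 2.4-fold lower number from compound 1 to compound 3 (0.38 log units; beyond the scatter). The remaining step, a 3.1-fold lower number from compound 1 to compound 2 (0.49 log units; beyond the scatter), is likewise modest.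

Compound 4 `COc1c(F)ccc(F)c1C1CCN(c2ccn3c(CC4CC4)nnc3c2Cl)CC1` differs from compound 3 by 3,6-difluoro-2-methoxyphenyl in place of 3,4-difluoro-2-methoxyphenyl on a saturated ring carbon. Going by the values given here, the one step that bears on it, moving fluorines on a methoxyphenyl, is a 1.3-fold higher number from compound 2 to compound 3 (0.11 log units; within the scatter), within the scatter. Hence no change beyond the scatter is expected in this assay. For compound 4 the expected step is a 1.2-fold higher number from compound 3 to compound 4 (0.06 log units; within the scatter). Compound 4 is estimated at 30 nM, range 12 nM to 80 nM.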

Compound 4, half-maximal effective concentration: 7.5 nM
Compound 4: the middle estimate sits 4.0-fold (0.60 log units) above what was measured, and the stated range ends above it.
By their numbers in this assay, from the lowest: compound 4; then compounds 2 and 3 (each within the scatter of the next); then compound 1.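

In this assay, going by these compounds alone, the arrangement of the two fluorines on the methoxyphenyl ring matters at this saturated ring carbon, which the earlier compounds did not show: with the same atoms, the change to 3,6-difluoro-2-methoxyphenyl gives a 3.5-fold lower number from compound 3 to compound 4 (0.54 log units; beyond the scatter). This group also separates from the unfluorinated methoxyphenyl, with a 2.7-fold lower number from compound 2 to compound 4 (0.43 log units; beyond the scatter), and an 8.2-fold lower number from compound 1 to compound 4 (0.92 log units; beyond the scatter) is the largest step in the set. Nothing measured here accounts for the difference.

From the compounds shown here alone, whether an ethoxy group in place of the methoxy group keeps this low number remains open. So does the effect of a nitrile in place of either fluorine.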